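From Isopropyl to 2-Fluorocyclopropyl on a Shared Core

The source may report more compounds than this note shows. Statements on the series, on what has been measured and on what is new or still open speak of the compounds shown alone.

Compound 1 `CC(C)C(=O)N1CC2CC(C1)N2`: 71%
Compound 2 `O=C(CC1C=CCC1)N1CC2CC(C1)N2`: 94%

Both compounds were tested in an assay on SH-EP1 cells for agonist activity at Neuronal acetylcholine receptor; alpha4/beta2 (Homo sapiens), read by FLIPR and calcium flux; a higher number here means a larger maximal response, a lower number a smaller maximal response. Compound 1 gives the lower of the two numbers, 71%. Compound 2 gives 94%, a gap that lies beyond the usual scatter of such measurements. Compound 3 `O=C([C@H]1C[C@@H]1F)N1CC2CC(C1)N2` has not yet been measured. It differs from compound 1 in a single place: 2-fluorocyclopropyl in place of isopropyl on a carbonyl carbon. Among the measured compounds shown here, no pair of measured compounds shows exactly this change on the shared core, so there is no measured step to lean on; the expectation rests on compound 1 alone. The change is expected to give a small step in this assay, most likely upward, or none beyond the scatter, meaning a number 7 percentage points higher from compound 1 to compound 3 (within the scatter). Compound 3 is therefore estimated to reach 78%, with a likely range from 60% to 96%.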

Compound 3, largest response reached (Emax), in percent of the reference or control that the assay uses: 100%
Beside the measured number, compound 3's estimate is 22 percentage points below it; the whole stated range lies below it.
By their numbers in this assay, from the lowest: compound 1; then compounds 2 and 3 (each within the scatter of the next).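

Swapping the group on the carbonyl carbon changes the maximal response by itself: 2-fluorocyclopropyl in place of isopropyl gives a number 29 percentage points higher from compound 1 to compound 3 (beyond the scatter) in this assay. This is the only step shown between two compounds that differ in one place, so this rise can be tied to that single swap. In that swap a three-membered ring and a fluorine enter, while the count of hydrogen-bond donors and acceptors stays the same. No measurement shown here explains the rise, so its origin remains unknown.

Going by these compounds, what remains open is whether the ring or the fluorine carries the step, a question that plain cyclopropyl would help to answer. On these data alone, the role of the two defined stereocentres is also open, and the opposite arrangement of the 2-fluorocyclopropyl group would test it.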